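Working notes: compound 2 to compound 4, cell cytotoxicity

A few compounds are considered here, and "the series" means these few. Any claim that something is new, unique, unknown or untested is made for them only; others in the source may bear on it.

Measured so far in a functional assay on DU-145 cells (Homo sapiens) for cytotoxicity, read by MTT assay; a lower number here means a stronger inhibitor, a higher number a weaker inhibitor:
- compound 1, `CC(O)(CSc1ccc(Cl)cc1)c1nc(-c2ccc(Cl)cc2)no1`: 14500 nM
- compound 2, `CC(O)(CSc1ccc(Br)cc1)c1nc(-c2ccc([N+](=O)[O-])c(C(F)(F)F)c2)no1`: 1600 nM
- compound 3, `CC(O)(CSc1ccc(Br)cc1)c1nc(-c2ccccc2)no1`: > 100000 nM

Compound 3 gives only a limit of the assay in this assay, not a number; (the limit of > 100000 nM in this assay, at which 1 of the 3 values shown sits).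

Among the two numbers, compound 2 stands lowest; the nearest is compound 1, whose number is higher by a gap beyond the scatter. Compound 2 and compound 1 differ in more than one place, so nothing is drawn from that pair beyond the two values themselves.

Compound 4 is `CC(O)(CS(=O)(=O)c1ccccc1)c1nc(-c2ccc([N+](=O)[O-])c(C(F)(F)F)c2)no1`, not yet measured. It differs from compound 2 by a single change: phenylsulfonyl in place of (4-bromophenyl)sulfanyl on a saturated chain carbon, two bonds along the chain from an aromatic carbon and an oxygen on a saturated carbon.

Among the compounds with values here, no measured pair isolates this change, so its direction is unknown from the series. The working expectation is a weakening, with the step from compound 2 to compound 4 estimated at a 2.5-fold higher number from compound 2 to compound 4 (0.40 log units; beyond the scatter), which may still fall within the scatter. Compound 4 is therefore expected at 4000 nM, in the range 1000 nM to 20000 nM.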

Compound 4, half-maximal inhibitory concentration: > 100000 nM
Compound 4 ended at the assay's limit; the forecaster's own chance of this, stated with the estimate: 10%; at least 25-fold (1.39 log units) between middle value and limit.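

In this assay, within the data shown here, phenylsulfonyl in place of (4-bromophenyl)sulfanyl on this saturated chain carbon gives an at least 62-fold higher number from compound 2 to compound 4 (1.79 log units; beyond the scatter), the first step that isolates a single change, and it shows that this position is sensitive to the group it carries. Compound 4 gives > 100000 nM, which is a limit of the assay and not a number, so the step has no upper bound. The low value of compound 2 therefore does not carry over with the rest of the structure held fixed, and the series now has a second compound at the limit: the limit of > 100000 nM in this assay, at which 2 of the 4 values shown sit.

The change removes the bromine and adds the sulfonyl oxygens together, and the compounds shown do not tell which of the two carries the step. A phenylsulfanyl or a (4-bromophenyl)sulfonyl group at this place would separate them.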